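This account rests on a few compounds, and the source may have more. Where it says the series, first, only, none or still open, it means among the compounds named here.

Working notes on the sulfone series.

For the measured compounds named here, compound 2 `O=S(=O)(/C=C/c1ccc(Cl)cn1)c1cccc(F)c1` sits at the high end of the three numbers so far: in an assay on U2OS cells for activation of nuclear factor erythroid 2-related factor 2 (Homo sapiens), read by beta-arrestin recruitment, with a stated time of 6 h (on this read-out higher numbers stand for an effect only at larger amounts of compound and lower numbers for an effect already at smaller amounts), compound 2 gives 2500 nM. Its nearest neighbour is compound 3 `O=S(=O)(/C=C\c1ncccc1Cl)c1cccc(F)c1`, which gives 2160 nM; furthest is compound 1 `O=S(=O)(/C=C/c1ccccn1)c1cccc(F)c1`, which gives 1680 nM. All three lie within the scatter of one another, so no ordering among them can be claimed.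

The next member, compound 4 `O=S(=O)(/C=C/c1ccc(Cl)cn1)c1cccc(Cl)c1`, differs from compound 2 by chloro in place of fluoro on an aromatic carbon, placed on an aromatic carbon of a six-membered aromatic ring of carbon only. Going by the values given here, no measured pair changes that position, so nothing bears directly on this step. Among the compounds with values here, the one step that exists, a 1.5-fold higher number from compound 1 to compound 2 (0.17 log units; within the scatter), concerns a different ring and stays within the scatter; it hints only that small halogen changes have not moved the read-out so far.

The step from compound 2 to compound 4 is therefore expected to be a 1.0-fold lower number from compound 2 to compound 4 (0.02 log units; within the scatter), that is, none beyond the scatter. Compound 4 is estimated at 2400 nM in this assay, with a range of 900 nM to 6500 nM.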

Compound 4, half-maximal effective concentration: 1510 nM
Estimate against measurement, compound 4: 1.6-fold (0.20 log units) above; measured number inside the range.
By their numbers in this assay, from the lowest: compounds 4, 1, 3 and 2 (each within the scatter of the next).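

In this assay, for the compounds shown here, the first measured change at this position, chloro in place of fluoro on an aromatic carbon of a six-membered aromatic ring of carbon only, is a 1.7-fold lower number from compound 2 to compound 4 (0.22 log units; within the scatter) and so stays inside the scatter. Exchanging these two halogens at this place, meta to a large group, thus gives no shift that can be told from the scatter, something the earlier step of a 1.5-fold higher number from compound 1 to compound 2 (0.17 log units; within the scatter) on a different ring could not show. Nothing on hand gives a reason for this result.

Open, from the compounds shown here alone, is whether a group other than a halogen here, such as an amine, a methoxy or a carboxylic acid, would move the number beyond the scatter. Also open, going by these compounds, is whether chloro would give the same result on another carbon of that ring.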